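Removing a Benzyl Group from a Biaryl Amide

The source may report more compounds than this note shows. Statements on the series, on what has been measured and on what is new or still open speak of the compounds shown alone.

Two compounds sharing one amide core have been examined in an ADME assay on HEK293 cells (Homo sapiens) for cytotoxicity, read by CellTiter-Glo and resazurin assay, with a stated time of 72 h; on this read-out lower numbers stand for an effect already at smaller amounts and higher numbers for an effect only at larger amounts of compound. Among the measured compounds shown here, compound 1, `CCOC(=O)CCCCCOc1cccc(CN(C(=O)c2ccc(-c3ccc(C(C)=O)s3)cc2)C(C)C)c1`, is the first of them. In this assay compound 1 gives > 26000 nM, which is a limit of the assay rather than a measured number. Compound 2, `CCOC(=O)CCCCCOc1cccc(CN(C(=O)c2ccc(-c3cccc(OCc4ccccc4)c3)cc2)C(C)C)c1`, carries a benzyloxy group in place of the outer ring of compound 1. In this assay compound 2 gives > 26000 nM, again a limit and not a number. Where compound 2 stands is thus given only by the limit of > 26000 nM in this assay, at which 2 of the 2 values shown sit.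

Compound 3, `CCOC(=O)CCCCCOc1cccc(CN(C(=O)c2ccc(-c3cccc(O)c3)cc2)C(C)C)c1`, has not yet been measured. It differs from compound 2 by hydrogen in place of benzyl on an oxygen on an aromatic ring. For the measured compounds named here, no measured pair shows the effect of this kind of change, so the expectation rests on the two limits alone. The expected step is a step that the limit leaves unreadable from compound 2 to compound 3, with no direction beyond the usual scatter. Compound 3 is therefore expected to give about 30000 nM, within a range from 12000 nM to 80000 nM, and most likely the assay will once more report only a limit.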

Compound 3, half-maximal effective concentration: > 26000 nM
Compound 3 ended at the assay's limit; the forecaster's own chance of this, stated with the estimate: 70%; the middle value lies beyond the limit too.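

In this assay compound 1, compound 2 and compound 3 all sit at a limit rather than a number, so no step from compound 2 or compound 1 to compound 3 can be read: the limit of > 26000 nM in this assay, at which 3 of the 3 values shown sit.

The compounds shown leave open how far the change from benzyloxy to hydroxy would shift a value that falls within the measurable range.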